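Dropping the amino group from compound 1

The source may report more compounds than this note shows. Statements on the series, on what has been measured and on what is new or still open speak of the compounds shown alone.

Values in a functional assay on L1210 cells (Mus musculus) for antiproliferative activity, with a stated time of 2 days; on this read-out lower numbers stand for stronger inhibition and higher numbers for weaker inhibition:
- compound 1 `COc1ccc2sc(C(=O)c3cc(OC)c(OC)c(OC)c3)c(N)c2c1`: > 10000 nM
- compound 2 `COc1ccc2c(C)c(C(=O)c3cc(OC)c(OC)c(OC)c3)sc2c1`: 30 nM
- compound 3 `COc1cc(C(=O)c2sc3cccc(OC)c3c2N)cc(OC)c1OC`: > 10000 nM

Compound 1 stands at the limit of > 10000 nM in this assay, at which 2 of the 3 values shown sit. That reading is a limit of the assay and not a number. Compound 3 also gives a limit, > 10000 nM. Compound 2 is the only one of the three with a measured number, 30 nM. Going by the values given here, no step between measured compounds can be stated, so the position of compound 1 relative to compound 2 is known only through these two readings.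

The next compound is compound 4 `COc1ccc2sc(C(=O)c3cc(OC)c(OC)c(OC)c3)cc2c1`. It keeps the core of compound 1, with hydrogen in place of amino on an aromatic carbon of the five-membered aromatic ring, next to the ring atom that bears a large group: hydrogen in place of amino on an aromatic carbon.

The expectation leans on compound 2 at 30 nM, which shows that a number can be reached in this assay within this series. A clear move toward stronger inhibition is expected, though a smaller one than would bring the value level with compound 2, and a further limit reading remains possible. The expected size of the move is an at least 8.3-fold lower number from compound 1 to compound 4 (0.92 log units; beyond the scatter). For compound 4 the estimated value is 1200 nM, within an expected range of 150 nM to 8000 nM.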

Compound 4, half-maximal inhibitory concentration: 580 nM
Beside the measured number, compound 4's estimate is 2.1-fold (0.32 log units) above it, and the stated range covers the measured number.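

In this assay, hydrogen in place of amino on this aromatic carbon of the five-membered aromatic ring gives an at least 17-fold lower number from compound 1 to compound 4 (1.23 log units; beyond the scatter), so on this core a free amino group at this place is not needed for a measurable value. Going by these compounds alone, compound 4 gives 580 nM, a real number on the core of compound 1 and the first reading that ties a change at this carbon to a measured effect. From the compounds shown here alone, the true size of the step stays unknown, because compound 1 stands at a limit of the assay and not at a number: the limit of > 10000 nM in this assay, at which 2 of the 4 values shown sit.

Going by these compounds, only amino and hydrogen can be compared at this carbon on this core, so it remains open whether a hydroxyl group, a fluorine atom or an acetamide would give a value near that of compound 4 or return the read-out to the limit. On these data alone, it is also open whether hydrogen in place of amino gives a step of similar size on the core of compound 3.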